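The source may report more compounds than this note shows. Statements on the series, on what has been measured and on what is new or still open speak of the compounds shown alone.

Compound 1 `O=C(CCCCCCN1C(=O)/C(=N\O)c2cc(F)ccc21)NO` has the lowest number of the three measured compounds in a functional assay on SW-620 cells (Homo sapiens) for antiproliferative activity, read by sulforhodamine B assay, with a stated time of 48 h (on this read-out higher numbers stand for weaker inhibition and lower numbers for stronger inhibition), where compound 1 gives 110 nM. Compound 2 `O=C(CCCCCCN1C(=O)/C(=N\O)c2cc(Cl)ccc21)NO` gives 650 nM, and compound 3 `O=C(CCCCCCN1C(=O)/C(=N\O)c2cc(Br)ccc21)NO` gives 290 nM. The unmeasured compound 4 `O=C(CCCCCCN1C(=O)/C(=N\O)c2cc([N+](=O)[O-])ccc21)NO` differs from compound 1 in a single place: nitro in place of fluoro on an aromatic carbon. Among the compounds with values here, no measured step involves a nitro group, so the only guides are the two other replacements of fluoro at the same place, a 5.9-fold higher number from compound 1 to compound 2 (0.77 log units; beyond the scatter) and a 2.6-fold higher number from compound 1 to compound 3 (0.42 log units; beyond the scatter), both modest rises. On that basis a modest rise beyond the scatter is expected for compound 4, a 2.7-fold higher number from compound 1 to compound 4 (0.44 log units; beyond the scatter), though with a wide range. The estimate for compound 4 is 300 nM, between 100 nM and 900 nM.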

Compound 4, half-maximal inhibitory concentration: 3390 nM
Compound 4: middle estimate off by 11-fold (1.05 log units), on the low side, outside the stated range (above it).
By their numbers in this assay, from the lowest: compound 1; then compound 3; then compound 2; then compound 4.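

In this assay, nitro gives the weakest compound of the four, with a 31-fold higher number from compound 1 to compound 4 (1.49 log units; beyond the scatter), a 12-fold higher number from compound 3 to compound 4 (1.07 log units; beyond the scatter) and a 5.2-fold higher number from compound 2 to compound 4 (0.72 log units; beyond the scatter), all beyond the scatter. This position is therefore more sensitive to the group placed on it than the three halogens alone showed, since a replacement of fluoro here can produce a large step and not only a modest one. Nothing available explains why nitro behaves this way. The compounds shown leave open how an amine, a methoxy group or a nitrile would compare at this place, and whether plain hydrogen would fall nearer to fluoro or to nitro.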